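Swapping the aryl group on the piperidine core of compound 3

This account rests on a few compounds, and the source may have more. Where it says the series, first, only, none or still open, it means among the compounds named here.

Three compounds share a core in which an amide links a substituted benzoyl group to a saturated ring carbon bearing an aromatic group. In an assay on cells for inhibition of sodium- and chloride-dependent glycine transporter 1 (Homo sapiens) (a lower number here means that less compound is needed, a higher number that more compound is needed for the effect), compound 1 `CN1CCCC(NC(=O)c2ccc(C(F)(F)F)cc2F)(c2ccccc2)C1` gives 9900 nM, compound 2 `Cc1cc(C(F)(F)F)ccc1C(=O)NC1(c2ccccc2)CCCN(C)C1` gives 320 nM, and compound 3 `COc1cc(C(F)(F)F)cc(SC)c1C(=O)NC1(c2ccc(C)cc2)CCCN(C)C1` gives 230 nM; compound 3 shows the lowest number, though its gap to compound 2 lies within the scatter. Going by the values given here, the one measured step, a 31-fold lower number from compound 1 to compound 2 (1.49 log units; beyond the scatter), concerns the benzoyl ring only. Compound 4 `COc1cc(C(F)(F)F)cc(SC)c1C(=O)NC1(c2ccncn2)CCCN(C)C1` differs from compound 3 elsewhere: pyrimidin-4-yl in place of 4-methylphenyl on a saturated ring carbon. Among the compounds with values here, no measured step bears on this change, so the expectation is uncertain; a modest rise is estimated, a 3.0-fold higher number from compound 3 to compound 4 (0.48 log units; beyond the scatter), giving compound 4 an expected value of about 700 nM in this assay, within a range of 200 nM to 2500 nM.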

Compound 4, half-maximal effective concentration: 1700 nM
Estimate against measurement, compound 4: 2.4-fold (0.39 log units) below; the measured number falls inside the stated range.
By their numbers in this assay, from the lowest: compounds 3 and 2 (each within the scatter of the next); then compound 4; then compound 1.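

Going by these compounds alone, the first step at this position comes with pyrimidin-4-yl in place of 4-methylphenyl on the saturated ring carbon: in this assay it gives a 7.4-fold higher number from compound 3 to compound 4 (0.87 log units; beyond the scatter). Within the data shown here, the position therefore responds to the choice of aromatic group even with the benzoyl part held constant, which the earlier compounds could not show. No measurement here explains the rise.

On these data alone, it remains open whether pyridin-4-yl or 4-chlorophenyl at this position would stay closer to compound 3. As far as these compounds go, it is also open whether the step would be the same size with the benzoyl group of compound 2.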